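Propylidene in place of the dimethylaminophenyl arylidene

A few compounds are considered here, and "the series" means these few. Any claim that something is new, unique, unknown or untested is made for them only; others in the source may bear on it.

Compound 2 `CC(=O)OC[C@H]1O[C@@H](n2cc(CN3C(=O)/C(=C\c4ccc(N(C)C)cc4)c4ccccc43)nn2)[C@H](OC(C)=O)[C@@H](OC(C)=O)[C@@H]1OC(C)=O` gives 25000 nM in a functional assay on HeLa cells (Homo sapiens) for cytotoxicity, read by sulforhodamine B assay, with a stated time of 48 h (a higher number here means a weaker inhibitor, a lower number a stronger inhibitor), and stands lowest of the two numbers shown; compound 3 `CC(=O)OC[C@H]1O[C@@H](n2cc(CN3C(=O)/C(=C/c4ccc(N(C)C)cc4)c4ccccc43)nn2)[C@H](OC(C)=O)[C@@H](OC(C)=O)[C@@H]1OC(C)=O` gives 26300 nM. The step of a 1.1-fold higher number from compound 2 to compound 3 (0.02 log units; within the scatter) shows the drawn configuration of the double bond makes no difference beyond the scatter, as seen from the fact that compounds 2 and 3 differ only in the configuration as drawn. Compound 1 `CC(=O)OC[C@H]1O[C@@H](n2cc(Cn3cc(/C=C4/C(=O)Nc5ccc(F)cc54)c4ccccc43)nn2)[C@H](OC(C)=O)[C@@H](OC(C)=O)[C@@H]1OC(C)=O` gives only a limit, > 200000 nM, in this assay, as recorded in the limit of > 200000 nM in this assay, at which 1 of the 3 values shown sits.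

Compound 4 `CCC/C=C1\C(=O)N(Cc2cn([C@@H]3O[C@H](COC(C)=O)[C@@H](OC(C)=O)[C@H](OC(C)=O)[C@H]3OC(C)=O)nn2)c2ccccc21` differs from compound 2 by propyl in place of 4-(dimethylamino)phenyl on a double-bonded chain carbon bound to a double-bonded ring carbon. For the measured compounds named here, no measured step covers a change at this place: the one step with a number concerns configuration only, and compound 1 carries a different core and sits at a limit. The expected step of a 2.0-fold higher number from compound 2 to compound 4 (0.30 log units; within the scatter) is therefore a guess toward a higher number, with wide bounds and a fair chance that the assay again returns only a limit. Compound 4 is estimated to give 50000 nM in this assay. The range for compound 4 is estimated as 15000 nM to 200000 nM.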

Compound 4, half-maximal inhibitory concentration: 46300 nM
The estimate for compound 4 lay 1.1-fold (0.03 log units) above the measured number; low and high end bracket the measured number.
By their numbers in this assay, from the lowest: compounds 2, 3 and 4 (each within the scatter of the next). At a limit, above all of these: compound 1.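

Propyl in place of 4-(dimethylamino)phenyl on a double-bonded chain carbon bound to a double-bonded ring carbon gives the first reading of a change at this place: in this assay, a 1.9-fold higher number from compound 2 to compound 4 (0.27 log units; within the scatter). The six-membered aromatic ring and its nitrogen can therefore leave this place without a step beyond the scatter, so for compound 2 and compound 4 the value does not depend on that ring. Nothing measured here bears on why this step stays so small.

From the compounds shown here alone, whether a longer chain, an amine or a carboxylic acid at this place would move the number in this assay beyond the scatter stays open. Going by these compounds, it is also open whether the configuration of the double bond matters as little with propyl as it does with 4-(dimethylamino)phenyl.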